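Moving the chlorine and nitrogen on the urea aryl ring

The source may hold more compounds than are shown below. What is called first, only, known or untested is meant among the compounds shown, and "the series" means these compounds.

Measured so far in a functional assay on Shh Light II cells (Mus musculus) for inhibition, read by a luciferase reporter; a lower number here means a stronger inhibitor, a higher number a weaker inhibitor:
compound 1 `CC(C)c1ccccc1NC(=O)N1CCC(c2nc(-c3ccc4ccccc4n3)no2)CC1` gives 480 nM
compound 2 `O=C(Nc1ncccc1Cl)N1CCC(c2nc(-c3ccc4ccccc4n3)no2)CC1` gives 2800 nM

Compound 2 holds the higher, and so weaker, of the two numbers at 2800 nM in this assay and is the starting point here. The next analogue is compound 3 `O=C(Nc1cccnc1Cl)N1CCC(c2nc(-c3ccc4ccccc4n3)no2)CC1`, which has the same atoms joined differently: 2-chloropyridin-3-yl in place of 3-chloropyridin-2-yl on an amide-type nitrogen gives 2-chloropyridin-3-yl in place of 3-chloropyridin-2-yl on an amide-type nitrogen.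

Within the data shown here, only one measured step bears on this change. It is a 5.8-fold higher number from compound 1 to compound 2 (0.77 log units; beyond the scatter) and is modest but beyond the scatter. That step replaced 2-isopropylphenyl with 3-chloropyridin-2-yl on the same amide-type nitrogen, so it shows that changes there can register in this assay but gives no direction for exchanging one chloropyridinyl group for another. Among the measured compounds shown here, no measured pair isolates such an exchange. A smaller shift than that step is therefore expected, probably not beyond the scatter. The expected step is a 1.4-fold lower number from compound 2 to compound 3 (0.15 log units; within the scatter) with only a slight lean and low confidence in its direction. The estimate for compound 3 is 2000 nM with an expected range of 700 nM to 6000 nM for a single measurement.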

Compound 3, half-maximal inhibitory concentration: 1600 nM
Beside the measured number, compound 3's estimate is 1.3-fold (0.10 log units) above it, within the range that was stated.
By their numbers in this assay, from the lowest: compound 1; then compounds 3 and 2 (each within the scatter of the next).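

Among these compounds, exchanging 3-chloropyridin-2-yl for 2-chloropyridin-3-yl on the amide-type nitrogen gives a 1.8-fold lower number from compound 2 to compound 3 (0.24 log units; within the scatter) in this assay, so this exchange, the first between two chloropyridinyl groups, does not separate them. Both chloropyridinyl compounds stand apart from the 2-isopropylphenyl compound: alongside a 5.8-fold higher number from compound 1 to compound 2 (0.77 log units; beyond the scatter), the new comparison gives a 3.3-fold higher number from compound 1 to compound 3 (0.52 log units; beyond the scatter), so the gap to compound 1 persists with either chloropyridinyl group, although both steps remain modest. No supporting data are available to explain these numbers.

Compound 1 differs from compound 2 and compound 3 in both the ring nitrogen and the substituent, so the contribution of each to the gap remains unresolved. A chlorophenyl group or an unsubstituted pyridinyl group on the same amide-type nitrogen would help separate the two, and an isopropyl-bearing pyridinyl group would test whether the ring nitrogen can be carried alongside the isopropyl substituent in this assay.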